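A Hydroxy(phenyl)methyl Replacement for Phenylsulfanyl

The compounds below may be only part of what the source reports. "The series", "measured", "known", "first", "only" and "open" are said of these compounds alone.

Compound 1 `CC(C)CN(CC(C)C)S(=O)(=O)c1ccc(NC(=O)C(C)(O)C(F)(F)F)cc1` and compound 2 `CC(O)(C(=O)Nc1ccc(Sc2ccccc2)cc1)C(F)(F)F` share a trifluoromethyl-bearing hydroxy amide attached to an aromatic ring, and both were tested in an assay on a protein complex (Cavia porcellus) with sulfonylurea receptors; K-ATP channels (Homo sapiens) as the target; a higher number here means a weaker inhibitor, a lower number a stronger inhibitor. For compound 1 the result is only a limit, > 30000 nM. For compound 2 likewise only a limit is known, > 30000 nM. Compound 2 therefore stands at the edge of what the measurement can report, and together the two compounds sit at the limit of > 30000 nM in this assay, at which 2 of the 2 values shown sit; neither gives a number to anchor a comparison.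

Compound 3 `CC(O)(C(=O)Nc1ccc([C@@H](O)c2ccccc2)cc1)C(F)(F)F` has not yet been tested. It differs from compound 2 in one place: hydroxy(phenyl)methyl in place of phenylsulfanyl on an aromatic carbon. Within the data shown here, no measured step exists for this kind of change, and nothing among the two known values points in either direction. Because both known values sit at the limit of > 30000 nM in this assay, at which 2 of the 2 values shown sit, the most that can be said is that compound 2 is weak in this assay. Compound 3 is expected to remain a weak inhibitor, its step estimated as a number no higher from compound 2 to compound 3 (the limit leaves the size open). The estimate for compound 3 in this assay is 30000 nM, within 10000 nM to 100000 nM, and most likely again only a limit.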

Compound 3, half-maximal inhibitory concentration: > 30000 nM
Compound 3 ended at the assay's limit; the forecaster's own chance of this, stated with the estimate: 70%; the middle value lies on the limit itself.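

In this assay compound 3 gives > 30000 nM, a limit of the assay and not a number. Among these compounds, no step from compound 2 to compound 3 can be read, because both stand at that limit: the limit of > 30000 nM in this assay, at which 3 of the 3 values shown sit.

The compounds shown leave open how strongly any of them inhibits, and whether hydroxy(phenyl)methyl in place of phenylsulfanyl changes that at all.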